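Swapping Two Methyl Groups for a Single Bromine

This account rests on a few compounds, and the source may have more. Where it says the series, first, only, none or still open, it means among the compounds named here.

Of the compounds shown here, three from one series have been measured in a functional assay on BGC-823 cells (Homo sapiens) for inhibition, read by CCK-8 assay, with a stated time of 48 h; on this read-out lower numbers stand for stronger inhibition and higher numbers for weaker inhibition. Compound 1 `Brc1ccc(C2=NN(C3=NC(c4ccccc4)CS3)C(c3ccc4ccccc4c3)C2)cc1` gives 13000 nM, compound 2 `Fc1ccc(C2=NN(C3=NC(c4ccccc4)CS3)C(c3cccc4ccccc34)C2)cc1` gives 22700 nM, and compound 3 `Cc1ccc(C2=NN(C3=NC(c4ccccc4)CS3)C(c3cccc4ccccc34)C2)cc1C` gives 8460 nM. Among the measured compounds shown here, compound 3 shows the lowest of the three numbers; its gap to compound 1 lies within the scatter, while the one measured step, a 2.7-fold lower number from compound 2 to compound 3 (0.43 log units; beyond the scatter), lies beyond it.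

Compound 4 `Brc1ccc(C2=NN(C3=NC(c4ccccc4)CS3)C(c3cccc4ccccc34)C2)cc1` follows from compound 3 by a single change: 4-bromophenyl in place of 3,4-dimethylphenyl on a carbon with a double bond to nitrogen. For the measured compounds named here, no measured step matches this exact exchange. Going by the values given here, the only step known, from compound 2 to compound 3, concerns a different pair of groups on the same carbon, so it speaks to the place but not to the bromine. Compound 1, which carries the same 4-bromophenyl group beside a differently attached naphthyl, sits close to compound 3, so the change in a 1.7-fold higher number from compound 3 to compound 4 (0.22 log units; within the scatter) is expected to be small, probably toward a somewhat higher number. Compound 4 is therefore estimated at 14000 nM, with a likely range from 6500 nM to 30000 nM.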

Compound 4, half-maximal inhibitory concentration: 17400 nM
Compound 4: middle estimate off by 1.2-fold (0.09 log units), on the low side; the measured number falls inside the stated range.
By their numbers in this assay, from the lowest: compounds 3, 1, 4 and 2 (each within the scatter of the next, the first and the last beyond it).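

In this assay, the exchange on the carbon with a double bond to nitrogen gives a 2.1-fold higher number from compound 3 to compound 4 (0.31 log units; beyond the scatter), so 3,4-dimethylphenyl and 4-bromophenyl can be told apart at this place, though only by a modest step. Two further comparisons stay within the scatter: bromo in place of fluoro gives a 1.3-fold lower number from compound 2 to compound 4 (0.12 log units; within the scatter), and naphthalen-1-yl in place of naphthalen-2-yl gives a 1.3-fold higher number from compound 1 to compound 4 (0.13 log units; within the scatter), so neither exchange separates its pair of compounds. No independent measurement is available to explain the difference between the 3,4-dimethylphenyl and 4-bromophenyl compounds.

The compounds shown leave open how a methoxy group, a hydroxyl group or an amine on this phenyl ring would read. They also leave open whether a single methyl group would match the 3,4-dimethylphenyl result.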